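Removing a Ring Fluorine in Two Related Antiproliferative Compounds

This account rests on a few compounds, and the source may have more. Where it says the series, first, only, none or still open, it means among the compounds named here.

So far, three compounds have been measured in a functional assay on HCT-116 cells (Homo sapiens) for antiproliferative activity, with a stated time of 72 h; a higher number here means a weaker inhibitor, a lower number a stronger inhibitor. Compound 1 `O=C(COc1ccc(CN2CC=C(c3c[nH]c4cccc(F)c34)CC2)c(F)c1)NO` gives 1220 nM in this assay. Compound 2 `Cc1ccc2[nH]cc(C3=CCN(Cc4ccc(OCC(=O)NO)cc4F)CC3)c2c1` gives 1450 nM in this assay. Compound 3 `O=C(COc1ccc(CN2CC=C(c3c[nH]c4cccc(F)c34)CC2)cc1)NO` gives 969 nM in this assay. The cores of the first two compounds differ in one way, (5-methyl-1H-indol-3-yl in place of 4-fluoro-1H-indol-3-yl on a double-bonded ring carbon), and in this assay that gave a 1.2-fold higher number from compound 1 to compound 2 (0.08 log units; within the scatter). Compound 3 is made from compound 1 by a single change, (hydrogen in place of fluoro on an aromatic carbon), which produced a step of a 1.3-fold lower number from compound 1 to compound 3 (0.10 log units; within the scatter). Compound 4 `Cc1ccc2[nH]cc(C3=CCN(Cc4ccc(OCC(=O)NO)cc4)CC3)c2c1` has not yet been measured; it stands to compound 2 as compound 3 stands to compound 1, the change being (hydrogen in place of fluoro on an aromatic carbon), the same change at the same place on a different core. Because the earlier step of a 1.3-fold lower number from compound 1 to compound 3 (0.10 log units; within the scatter) stayed within the scatter, the change from compound 2 to compound 4 is expected to be of similar size, a 1.3-fold lower number from compound 2 to compound 4 (0.12 log units; within the scatter). Compound 4 is therefore estimated at 1100 nM in this assay, with a likely range from 550 nM to 2300 nM.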

Compound 4, half-maximal inhibitory concentration: 632 nM
Compound 4: middle estimate off by 1.7-fold (0.24 log units), on the high side, within the range that was stated.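

In this assay, hydrogen in place of fluoro on the aromatic carbon gave a 2.3-fold lower number from compound 2 to compound 4 (0.36 log units; beyond the scatter). This step lies beyond the scatter while the earlier one on the core of compound 1 does not, yet the gap between the two is itself within the scatter: the same change on two cores in this assay, a 1.3-fold lower number (0.10 log units; within the scatter) from compound 1 to compound 3 and a 2.3-fold lower number (0.36 log units; beyond the scatter) from compound 2 to compound 4, 1.8-fold (0.26 log units) apart, within the scatter of two such steps The pairs therefore give no sign that the outcome of this change depends on the core, and the larger step seen here cannot be taken as a real difference between the two cores, but two pairs cannot show that the change would carry over in the same way to any other core in the series.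

The compounds shown leave open how a chlorine, a methoxy group or an amine would compare with hydrogen and fluoro on the same aromatic carbon. They also leave open whether the change would give a similar step with a longer chain in place of the (hydroxycarbamoyl)methoxy group.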